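Ketone to ester at the carbonyl on a two-compound set

The compounds below may be only part of what the source reports. "The series", "measured", "known", "first", "only" and "open" are said of these compounds alone.

Of the compounds shown here, two carry numbers so far. Compound 1 `CC1=C(C(=O)OCc2ccccc2)C(c2ccco2)NC(=O)N1` bears a benzyl ester on the shared core; in an assay on membranes from HEK293 cells for displacement of a labelled ligand from adenosine receptor A2b (Homo sapiens), read by scintillation counting, with a stated time of 30 min (on this read-out lower numbers stand for stronger inhibition and higher numbers for weaker inhibition), compound 1 gives 887 nM. Compound 2 `CCCC(=O)C1=C(C)NC(=O)NC1c1ccco1` bears a propyl ketone in the same place, and in this assay compound 2 gives 807 nM. The two values lie within the usual scatter of each other, so neither compound can be called stronger or weaker than the other. Among the measured compounds shown here, the pair differs in more than one place, so no single step is computed between them.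

Compound 3 `CCC(C)OC(=O)C1=C(C)NC(=O)NC1c1ccco1` has not yet been measured. Against compound 2 the change is sec-butoxy in place of propyl on a carbonyl carbon, which turns the ketone into an ester. The step from compound 2 to compound 3 a 1.1-fold higher number from compound 2 to compound 3 (0.05 log units; within the scatter) is expected to be none beyond the scatter, since compound 1, also an ester, gives 887 nM. Compound 3 is therefore expected near 900 nM, within 300 nM to 2700 nM.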

Compound 3, inhibition constant: 84.3 nM
Beside the measured number, compound 3's estimate is 11-fold (1.03 log units) above it, outside the stated range (below it).
By their numbers in this assay, from the lowest: compound 3; then compounds 2 and 1 (each within the scatter of the next).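

In this assay, among the compounds shown here, the group on this carbonyl carbon decides a great deal: sec-butoxy in place of propyl gives a 9.6-fold lower number from compound 2 to compound 3 (0.98 log units; beyond the scatter), the first step beyond the scatter. Turning the ketone into an ester does not account for this by itself, since sec-butyl in place of benzyl on an oxygen next to a carbonyl group gives an 11-fold lower number from compound 1 to compound 3 (1.02 log units; beyond the scatter), so the two esters are far apart. Compound 1 and compound 2 lie within the scatter of each other and gave no hint that this position could separate compounds so widely.

Still open, going by these compounds, is whether a straight-chain butyl, an ethyl or a cyclopentyl group on that oxygen would match compound 3, which would show whether the branched chain matters. For the compounds shown here, nothing measured so far explains the size of either step.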